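The compounds below may be only part of what the source reports. "The series", "measured", "known", "first", "only" and "open" are said of these compounds alone.

Measured in an ADME assay on U2OS cells (Homo sapiens) for cytotoxicity; a lower number here means that less compound is tolerated, a higher number that more compound is tolerated:
- compound 1 `CCSc1ccc(-c2nccc3[nH]c(C(C)(C)O)cc23)cc1`: 17200 nM
- compound 2 `CC(C)(O)c1cc2c(-c3cc(C(F)(F)F)cc(C(F)(F)F)c3)nccc2[nH]1`: 59800 nM

Compound 1 stands lowest of the two, and the gap up to compound 2 lies beyond the scatter. Compound 3 `Cc1ccc(-c2nccc3[nH]c(C(C)(C)O)cc23)cc1` follows from compound 1 by one change, methyl in place of ethylsulfanyl on an aromatic carbon. Within the data shown here, no measured pair differs in one place only, so the size of this step rests on judgement. The step expected in this assay is small, a 1.6-fold higher number from compound 1 to compound 3 (0.21 log units; within the scatter), toward a higher number and perhaps not beyond the scatter. For compound 3 the estimate is 28000 nM, with an expected range from 9000 nM to 80000 nM.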

Compound 3, half-maximal cytotoxic concentration: 38500 nM
For compound 3 the middle estimate is 1.4-fold (0.14 log units) below the measured one; measured number inside the range.
By their numbers in this assay, from the lowest: compound 1; then compounds 3 and 2 (each within the scatter of the next).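

In this assay, methyl in place of ethylsulfanyl on an aromatic carbon para to a large group gives a 2.2-fold higher number from compound 1 to compound 3 (0.35 log units; beyond the scatter), so more compound is tolerated with the smaller group in this place. Among these compounds, this is the first single change that can be read at this position, and it shows that the position affects the result in this assay. Nothing available explains the size or direction of this step. Going by these compounds, what an ethyl group, a methylsulfanyl group or an amine would do on this carbon remains open, as does whether the sulfur or the chain length carries the step.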